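The compounds below may be only part of what the source reports. "The series", "measured", "known", "first", "only" and "open" are said of these compounds alone.

Notes on the series around the shared core. Compound 1 `CC(=O)N1N=C(c2cc3ccccc3nc2C)CC1/C=C/c1ccccc1` in an ADME assay on A549 cells (Homo sapiens) for cytotoxicity, read by MTT assay, with a stated time of 48 h (on this read-out lower numbers stand for stronger inhibition and higher numbers for weaker inhibition), gives 93.3 ug/mL. Compound 2 `CC(=O)N1N=C(c2cc3ccccc3nc2C)CC1c1ccc([N+](=O)[O-])cc1` in this assay reaches only the assay limit, > 200 ug/mL. The step of an at least 2.1-fold higher number from compound 1 to compound 2 (0.33 log units; beyond the scatter) therefore rests on the limit of > 200 ug/mL in this assay, at which 1 of the 2 values shown sits, and its true size is open-ended. Compound 3 `CC(=O)N1N=C(c2cc3ccccc3nc2C)CC1c1ccc(N(C)C)cc1` is not yet measured; it differs from compound 2 by dimethylamino in place of nitro on an aromatic carbon. Among the measured compounds shown here, no measured step bears on this change, so the step of an at least 1.1-fold lower number from compound 2 to compound 3 (0.04 log units; that floor lies within the scatter) is expected to be none beyond the scatter, with a real chance of another limit. Compound 3 is expected at 180 ug/mL, between 80 ug/mL and 400 ug/mL.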

Compound 3, half-maximal inhibitory concentration: 110 ug/mL
Compound 3: the middle estimate sits 1.6-fold (0.21 log units) above what was measured; the measured number falls inside the stated range.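

In this assay, dimethylamino in place of nitro on an aromatic carbon gives an at least 1.8-fold lower number from compound 2 to compound 3 (0.25 log units; that floor lies within the scatter), so this position can carry a group that returns a measured number. On these data alone, the value of compound 2 is a limit, so the true size of that step stays open: the limit of > 200 ug/mL in this assay, at which 1 of the 3 values shown sits. Against the other substituent, 4-(dimethylamino)phenyl in place of 2-phenylethenyl gives a 1.2-fold higher number from compound 1 to compound 3 (0.07 log units; within the scatter), so these two groups are not told apart here.

As far as these compounds go, what a methoxy group, a chlorine atom or a primary amine would give at this aromatic carbon stays open.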